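The compounds below may be only part of what the source reports. "The series", "measured", "known", "first", "only" and "open" are said of these compounds alone.

In a functional assay on MCF7 cells (Homo sapiens) for inhibition, read by sulforhodamine B assay (a higher number here means a weaker inhibitor, a lower number a stronger inhibitor), compound 2 `O=C1C(NC2CCCC2)=CC(=O)c2c1nc1n2[C@H]2OC[C@@H](O)[C@H]2OC1` gives > 16000 nM, which is a limit and not a number. Compound 3 `O=C1C=C(NC2CCCCC2)C(=O)c2c1nc1n2[C@H]2OC[C@@H](O)[C@H]2OC1` gives > 8000 nM, which is also a limit. Going by the values given here, compound 1 `CCCc1ccc(NC2=CC(=O)c3nc4n(c3C2=O)[C@H]2OC[C@@H](O)[C@H]2OC4)cc1` is the only one with a true number, 4660 nM.

Compound 4 `COc1ccccc1NC1=CC(=O)c2c(nc3n2[C@H]2OC[C@@H](O)[C@H]2OC3)C1=O` keeps the core of compound 2 and changes only the group on the amine nitrogen: 2-methoxyphenyl in place of cyclopentyl on an amine nitrogen. In short, 2-methoxyphenyl takes the place of cyclopentyl. Among the compounds with values here, one measured step bears on this, an exchange in the opposite sense, from 4-propylphenyl to cyclohexyl, with an at least 1.7-fold higher number from compound 1 to compound 3 (0.23 log units; that floor lies within the scatter). The amine is attached differently on the core in that pair than in compound 2, so the guide is indirect. Read in reverse, the step offers only a weak hint that a phenyl group on this nitrogen lowers the number in this assay. A modest step down is therefore expected, and it may not clear the scatter. For compound 4 the expected value is 7000 nM, within an estimated range of 2500 nM to 20000 nM. This estimate amounts to an at least 2.2-fold lower number from compound 2 to compound 4 (0.35 log units; beyond the scatter).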

Compound 4, half-maximal inhibitory concentration: 6580 nM
Compound 4: the middle estimate sits 1.1-fold (0.03 log units) above what was measured; measured number inside the range.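

In this assay compound 2 gives > 16000 nM, which is a limit and not a number. Even against that limit, 2-methoxyphenyl in place of cyclopentyl on the amine nitrogen gives an at least 2.4-fold lower number from compound 2 to compound 4 (0.38 log units; beyond the scatter), so an aryl group on this nitrogen now has a step beyond the scatter, whereas the earlier exchange, read as an at least 1.7-fold higher number from compound 1 to compound 3 (0.23 log units; that floor lies within the scatter), reached only a floor within it. As far as these compounds go, this step also stands on a single attachment of the amine to the core, so it no longer rests on the indirect guide from the other attachment, though its full size stays unknown.

The compounds shown leave open whether the gain belongs to the aromatic ring or to the methoxy group, which a plain phenyl on the same nitrogen would separate. They also leave open how a 4-propylphenyl, or a ring carrying an amine or a carboxylic acid, would read at this attachment.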